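The source may report more compounds than this note shows. Statements on the series, on what has been measured and on what is new or still open speak of the compounds shown alone.

Working notes on the series. Compound 1 `COc1ccc2nc(C)cc(OCC(=O)Nc3ccccc3)c2c1` gives 39800 nM in a toxicity assay on HepG2 cells (Homo sapiens) for inhibition, read by CellTiter-Glo, with a stated time of 48 h; on this read-out lower numbers stand for stronger inhibition and higher numbers for weaker inhibition. Compound 2 `COc1ccc2nc(C)cc(OCC(=O)Nc3c(C)cccc3C)c2c1` sits at the limit of > 100000 nM in this assay, at which 1 of the 2 values shown sits, in this assay, reported as > 100000 nM and not as a number. Among the compounds with values here, the one measured step, an at least 2.5-fold higher number from compound 1 to compound 2 (0.40 log units; beyond the scatter), is the only guide available.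

Compound 3 `COc1ccc(NC(=O)COc2cc(C)nc3ccc(OC)cc23)cc1` differs from compound 2 by 4-methoxyphenyl in place of 2,6-dimethylphenyl on an amide-type nitrogen. Within the data shown here, this change takes away the 2,6-dimethylphenyl whose entry produced an at least 2.5-fold higher number from compound 1 to compound 2 (0.40 log units; beyond the scatter), so the number is expected to fall back toward the region of compound 1; no measured step covers the 4-methoxyphenyl itself, and compound 1 is the only anchor. The expected step is therefore an at least 2.0-fold lower number from compound 2 to compound 3 (0.30 log units; that floor lies within the scatter), downward and beyond the scatter, though a second limit readout remains possible. Compound 3 is estimated at 50000 nM in this assay, with a range from 20000 nM to 120000 nM.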

Compound 3, half-maximal inhibitory concentration: > 100000 nM
Compound 3: only a limit was reported (the forecaster's own chance of this, stated with the estimate: 35%); middle value at least 2.0-fold (0.30 log units) away from the limit.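

Methoxy in place of hydrogen on an aromatic carbon gives an at least 2.5-fold higher number from compound 1 to compound 3 (0.40 log units; beyond the scatter), so a higher number is not confined to the entry of 2,6-dimethylphenyl on the amide-type nitrogen. In this assay, within the data shown here, compound 1, with its unsubstituted phenyl, is now the only compound of the three with a measured number. Compound 2 and compound 3 are each reported only as a limit, so the step between them cannot be read: the limit of > 100000 nM in this assay, at which 2 of the 3 values shown sit.

Any order between 2,6-dimethylphenyl and 4-methoxyphenyl therefore stays open. Also open, on these data alone, is whether a single methyl, an amine or a carboxylic acid on the phenyl would return a measured number or would again give a limit.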